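Removing the bromine from a phenyl ring of compound 2

The compounds below may be only part of what the source reports. "The series", "measured", "known", "first", "only" and "open" are said of these compounds alone.

Compound 2 `C=CCOc1c(C)c(C)c2c(c1C)CCC(C)(COc1ccc(/C=C3\SC(=O)NC3=O)cc1Br)O2` carries a bromo group on the six-membered aromatic ring that also bears the thiazolidinedione side chain. In a functional assay on MCF7 cells (Homo sapiens), tested at 5 uM (on this read-out lower numbers stand for a stronger effect and higher numbers for a weaker effect at the one concentration tested), compound 2 gives 98%, the highest of the three numbers measured and therefore the weakest effect among them. Compound 3 `CC(C)=CCOc1c(C)c(C)c2c(c1C)CCC(C)(COc1ccc(/C=C3\SC(=O)NC3=O)cc1F)O2`, with a fluoro group at that place, gives 87%, and compound 1 `CCOc1cc(/C=C2\SC(=O)NC2=O)ccc1OCC1(C)CCc2c(C)c(OCC=C(C)C)c(C)c(C)c2O1`, with an ethoxy group there, gives 84%. Compound 4 `C=CCOc1c(C)c(C)c2c(c1C)CCC(C)(COc1ccc(/C=C3\SC(=O)NC3=O)cc1)O2` differs from compound 2 in one place: hydrogen in place of bromo on an aromatic carbon.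

Among the measured compounds shown here, only one measured step touches this position, a number 3 percentage points higher from compound 1 to compound 3 (within the scatter), and it stays within the usual scatter. For the measured compounds named here, no measured pair shows a bromo group traded for hydrogen, so the expectation rests on that small step alone. Compound 4 is therefore expected to give a number close to that of compound 2, perhaps slightly lower, with a step of a number 6 percentage points lower from compound 2 to compound 4 (within the scatter) that may not reach beyond the scatter. Compound 4 is estimated at 92%, within a range from 78% to 103%.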

Compound 4, a percentage reported as activity, at one concentration (the size of the read-out at that concentration, not a potency): 42%
Beside the measured number, compound 4's estimate is 50 percentage points above it, and the stated range ends above it.
By their numbers in this assay, from the lowest: compound 4; then compounds 1 and 3 (each within the scatter of the next); then compound 2.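

In this assay, the bromo group on this aromatic carbon proves to matter a great deal: replacing it with hydrogen gives a number 56 percentage points lower from compound 2 to compound 4 (beyond the scatter), a large move toward a stronger effect from the loss of one heavy atom. Among the compounds shown here, the only earlier step at this place, a number 3 percentage points higher from compound 1 to compound 3 (within the scatter), traded one group for another and showed no clear change, so it could not reveal what happens when the carbon carries only hydrogen. Nothing available here explains the size of this step.

As far as these compounds go, compound 1 and compound 3 carry a different ether chain on the core from compound 2 and compound 4, so it remains open whether hydrogen at this place gives a similar step with that chain. Also open, from the compounds shown here alone, is how a chloro group, a methyl group or an amine on this carbon would read compared with bromo and hydrogen.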